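This account rests on a few compounds, and the source may have more. Where it says the series, first, only, none or still open, it means among the compounds named here.

Three compounds with a shared core have numbers in an in vitro functional assay on HEK285-7 cells for antagonist activity at prostaglandin D2 receptor 2 (Homo sapiens), read by BRET and beta-arrestin recruitment; on this read-out lower numbers stand for smaller maximal responses and higher numbers for larger maximal responses. Compound 1 `COc1cc(-c2nc(C(c3ccc(F)cc3)c3ccc(F)cc3)sc2CC(=O)O)ccn1` gives 60% there. Compound 2 `O=C(O)Cc1sc(CSc2ccccc2)nc1-c1ccc(Cl)cc1` gives 50% in this assay, a number that lies within the usual scatter of that of compound 1, so the two cannot be told apart. Compound 3 `O=C(O)Cc1sc(C(c2ccccc2)c2ccccc2)nc1-c1cccc(F)c1` gives 80% in this assay, a number beyond the scatter above that of compound 1. Compound 1 therefore stands second of the three numbers, indistinguishable from compound 2 and clearly below compound 3.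

Compound 4 `O=C(O)Cc1sc(C(c2ccc(F)cc2)c2ccc(F)cc2)nc1-c1cc(F)nc(F)c1` has not been measured in this assay. Its structure differs from compound 1 in one place: 2,6-difluoropyridin-4-yl in place of 2-methoxypyridin-4-yl on an aromatic carbon. For the measured compounds named here, no pair of measured compounds shows what such a change does, so the expectation rests on the spread of the three numbers alone, which remains narrow. The step in this assay is expected to be none beyond the scatter: no change at the digits printed from compound 1 to compound 4 (within the scatter). Compound 4 is expected to give about 60% in this assay, estimated between 40% and 80%.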

Compound 4, largest response reached (reported as efficacy), in percent of the reference or control that the assay uses: 80%
Estimate against measurement, compound 4: 20 percentage points below; low and high end bracket the measured number.
By their numbers in this assay, from the lowest: compounds 2 and 1 (each within the scatter of the next); then compounds 3 and 4 (each within the scatter of the next).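

In this assay, putting 2,6-difluoropyridin-4-yl in place of 2-methoxypyridin-4-yl on the aromatic carbon next to the ring nitrogen gives a number 20 percentage points higher from compound 1 to compound 4 (beyond the scatter). For the compounds shown here, the earlier compounds offered no pair differing in one place, so this is the first sign that the group at this position can, on its own, move the maximal response while the rest of compound 1 stays unchanged. Nothing available explains this step.

The compounds shown leave open whether the step follows from the loss of the methoxy group or from the gain of the two fluorines, which a 2-fluoropyridin-4-yl or an unsubstituted pyridin-4-yl group could separate. They also leave open whether an amine on the pyridine ring, or the same exchange on a different large group, would shift the response similarly.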